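This account rests on a few compounds, and the source may have more. Where it says the series, first, only, none or still open, it means among the compounds named here.

Working notes on the series. Of the compounds shown here, three on one shared core have been measured in a functional assay (Homo sapiens); a lower number here means a stronger inhibitor, a higher number a weaker inhibitor. Compound 1 `Nc1nc2ccnc(-c3cc[n+]([O-])cc3)n2n1` gives 5600 nM. Compound 2 `Nc1nc2ccnc(-c3cccc(C=O)c3)n2n1` gives 700 nM. Compound 3 `Nc1nc2ccnc(-c3cc(C(F)(F)F)cc(C(F)(F)F)c3)n2n1` gives 700 nM. Compound 2 and compound 3 are level with each other at the digits shown, and together they hold the lowest numbers of the three; compound 1 stands furthest from compound 2, with a higher number beyond the scatter.

Compound 4 `CN(C)C(=O)c1cccc(-c2nccc3nc(N)nn23)c1` has not yet been measured in this assay. It differs from compound 2 in one place: dimethylamino in place of hydrogen on a carbonyl carbon. Going by the values given here, no pair of measured compounds carries this change, so there is nothing in hand to size it from; the expectation below rests on the structural change alone.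

The step from compound 2 to compound 4 is expected to be small, toward a somewhat higher number, and it may well fall within the scatter: a 1.4-fold higher number from compound 2 to compound 4 (0.15 log units; within the scatter). For compound 4 the estimate in this assay is 1000 nM, with a range from 300 nM to 3500 nM.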

Compound 4, half-maximal inhibitory concentration: 3500 nM
Estimate against measurement, compound 4: 3.5-fold (0.54 log units) below; low and high end bracket the measured number.
By their numbers in this assay, from the lowest: compounds 2 and 3 (each within the scatter of the next); then compounds 4 and 1 (each within the scatter of the next).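

Replacing hydrogen with dimethylamino on the carbonyl carbon gives, in this assay, a 5.0-fold higher number from compound 2 to compound 4 (0.70 log units; beyond the scatter). Going by these compounds alone, this is the first step that can be sized from a single change, and it shows that going from formyl to dimethylcarbamoyl at this place costs inhibition beyond the scatter, even though the carbonyl carbon and its aromatic carbon neighbour stay the same. Nothing in hand explains this loss.

Going by these compounds, whether a primary carboxamide, a methylamide, a methyl ketone or a carboxylic acid on this carbonyl carbon would stay close to compound 2 or to compound 4 remains open. The compounds shown also hold no second pair carrying this change, so it is not known whether the step would keep its size elsewhere in the series.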